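Working notes: fluoro for chloro on compound 3

A few compounds are considered here, and "the series" means these few. Any claim that something is new, unique, unknown or untested is made for them only; others in the source may bear on it.

Values in a functional assay on U-251 cells (Homo sapiens); a higher number here means a weaker inhibitor of growth, a lower number a stronger inhibitor of growth:
- compound 1 `O=S(=O)(/C=C/c1ccc(Cl)cc1Cl)Cc1ccc(Nc2ncnc3ccccc23)cc1`: 4000 nM
- compound 2 `O=S(=O)(/C=C/c1ccc(F)cc1Cl)Cc1ccc(Nc2ncnc3ccccc23)cc1`: 100000 nM
- compound 3 `O=S(=O)(/C=C/c1ccc(Cl)cc1Cl)Cc1ccc(Nc2ncnc3cc(Cl)ccc23)cc1`: 53000 nM
- compound 4 `O=S(=O)(/C=C/c1ccc(F)cc1Cl)Cc1ccc(Nc2ncnc3cc(Cl)ccc23)cc1`: not yet measured

Compound 3, at 53000 nM, lies within the scatter of compound 2, at 100000 nM. Both sit far from compound 1, and the gap on the compound 3 side is a 13-fold higher number from compound 1 to compound 3 (1.12 log units; beyond the scatter).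

The next change turns the 2,4-dichlorophenyl of compound 3 into the 2-chloro-4-fluorophenyl of compound 4: fluoro in place of chloro on an aromatic carbon. The same fluoro in place of chloro has been measured once, as a 25-fold higher number from compound 1 to compound 2 (1.40 log units; beyond the scatter). That is a large step, but it started from the low number of compound 1. The other measured step, chloro in place of hydrogen on an aromatic carbon, is a 13-fold higher number from compound 1 to compound 3 (1.12 log units; beyond the scatter), and compound 4 carries both changes. Within the data shown here, no measured set of compounds shows whether the two steps add up, and a full repeat of the first would land well past every number seen so far. A step in this assay towards a higher number is therefore expected, but much smaller than the measured one and possibly within the scatter.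

The estimated step is a 1.7-fold higher number from compound 3 to compound 4 (0.23 log units; within the scatter). Compound 4 is expected near 90000 nM, with an estimated range of 45000 nM to 180000 nM.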

Compound 4, concentration for 50% growth inhibition: 2000 nM
Compound 4: middle estimate off by 45-fold (1.65 log units), on the high side, outside the stated range (below it).
By their numbers in this assay, from the lowest: compounds 4 and 1 (each within the scatter of the next); then compounds 3 and 2 (each within the scatter of the next).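

Fluoro in place of chloro on this ring, para to a large group, has no fixed effect in this assay: with the extra chloro on the core it gives a 27-fold lower number from compound 3 to compound 4 (1.42 log units; beyond the scatter), the opposite direction to the only earlier case of this change: the same change on two cores in this assay, a 25-fold higher number (1.40 log units; beyond the scatter) from compound 1 to compound 2 and a 27-fold lower number (1.42 log units; beyond the scatter) from compound 3 to compound 4, 660-fold (2.82 log units) apart, beyond the scatter of two such steps

Chloro in place of hydrogen on the core also changes direction with the group on the phenyl ring, giving a 50-fold lower number from compound 2 to compound 4 (1.70 log units; beyond the scatter) when that ring is 2-chloro-4-fluorophenyl: the same change on two cores in this assay, a 13-fold higher number (1.12 log units; beyond the scatter) from compound 1 to compound 3 and a 50-fold lower number (1.70 log units; beyond the scatter) from compound 2 to compound 4, 660-fold (2.82 log units) apart, beyond the scatter of two such steps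

Neither change can therefore be read on its own in these four compounds, since the size and direction of each depend on the other, and the two steps do not add up.

The compounds shown leave open whether this dependence is limited to these halogens, which a bromo or methoxy group in place of the fluoro would begin to test. They also leave open whether a different group on the core, such as an amine in place of the chloro, would pair with the 2-chloro-4-fluorophenyl group in the same way.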